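The source may report more compounds than this note shows. Statements on the series, on what has been measured and on what is new or still open speak of the compounds shown alone.

Measured so far in an ADME assay on microsomes from liver (Rattus norvegicus, strain Sprague-Dawley) for metabolic stability, read by HPLC, using NADPH, with stated times of 5 min and 60 min, tested at 10 uM; on this read-out lower numbers stand for slow clearance and higher numbers for fast clearance:
compound 1 `CC(C)S(=O)(=O)Nc1ccc(CNC(=O)c2ccc(C(C)(C)C)cc2)c(Cl)c1` gives 23 mL.min-1.g-1
compound 2 `CC(C)(C)c1ccc(C(=O)NCc2ccc(NS(C)(=O)=O)cc2F)cc1` gives 47 mL.min-1.g-1
compound 3 `CN(C)c1ccc(C(=O)NCc2ccc(NS(C)(=O)=O)cc2Cl)cc1` gives 25 mL.min-1.g-1

Compound 3 sits with compound 1 and compound 2 inside one band: its gap to compound 1 and its gap to compound 2 are both within the usual scatter of this assay, so no ranking among the three measured compounds can be claimed, and nothing beyond noise separates them.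

The next compound, compound 4 `COC(C)(C)c1ccc(C(=O)NCc2ccc(NS(C)(=O)=O)cc2Cl)cc1`, is not yet measured. It differs from compound 3 in one place: 1-methoxy-1-methylethyl in place of dimethylamino on an aromatic carbon. The change sits on an aromatic carbon of a six-membered aromatic ring of carbon only, para to a large group; the rest of the shared core is unchanged.

Among the compounds with values here, no pair of measured compounds differing in a single place is available, so there is no measured step to lean on for this change. The three numbers seen so far are close, and the expectation is that compound 4 also stays close to them, with a step from compound 3 to compound 4 of a 1.2-fold higher number from compound 3 to compound 4 (0.08 log units; within the scatter), no larger than the scatter. For compound 4 in this assay the estimate is 30 mL.min-1.g-1, with a range from 14 mL.min-1.g-1 to 65 mL.min-1.g-1.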

Compound 4, intrinsic clearance in microsomes: 24 mL.min-1.g-1
Beside the measured number, compound 4's estimate is 1.3-fold (0.10 log units) above it, and the stated range covers the measured number.
By their numbers in this assay, from the lowest: compounds 1, 4, 3 and 2 (each within the scatter of the next, the first and the last beyond it).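

In this assay, within the data shown here, the first single-place step reads a 1.0-fold lower number from compound 3 to compound 4 (0.02 log units; within the scatter), with 1-methoxy-1-methylethyl in place of dimethylamino on an aromatic carbon, para to a large group. Among these compounds, at this position, then, a group of 5 heavy atoms carrying oxygen and one of 3 heavy atoms carrying nitrogen cannot be told apart on intrinsic clearance in microsomes, a comparison the earlier compounds, with no single-place pair among them, could not give. No measurement at hand bears on why the two groups read alike.

On these data alone, whether a carboxylic acid, a primary amine or a longer alkyl chain at this position would stay in the same band remains open. One step also leaves open whether this exchange would read the same on the core of compound 1.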